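Swapping a fluorophenyl for propyl on a thioether arm

The compounds below may be only part of what the source reports. "The series", "measured", "known", "first", "only" and "open" are said of these compounds alone.

Measured so far:
Compound 1 `CC(C)OC(=O)[C@H](C)NC(=O)c1ccc(Nc2nc(Cl)nc(Cl)n2)cc1` gives 3.02%
Compound 2 `O=c1nc(SCc2ccccc2)nc(SCc2cccc(F)c2)[nH]1` gives 4.18%

Both compounds were tested in an assay for inhibition of Pro-cathepsin H (Homo sapiens), read by fluorescence, tested at 50 uM; on this read-out lower numbers stand for less inhibition and higher numbers for more inhibition at the one concentration tested (going by the name of the read-out). Compound 1 gives 3.02% there, and compound 2 gives 4.18%. Compound 2 holds the higher of the two numbers, but the gap to compound 1 is within the scatter of repeated measurements, so the two compounds cannot be told apart on these data: both show only a small amount of inhibition at the single concentration tested.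

Compound 3 `CCCCSc1nc(SCc2ccccc2)nc(=O)[nH]1` is the next compound, not yet measured in this assay. It differs from compound 2 in one place: propyl in place of 3-fluorophenyl on a saturated chain carbon bound to a sulfur. Among the compounds with values here, no measured pair shows what such a change does, so the expectation rests on the level seen for compound 2 alone.

With both measured compounds sitting at a low level, no step beyond the scatter is expected in either direction. Compound 3 is expected to give 4%, with a range from -5% to 13%. This amounts to an expected a number 0.2 percentage points lower from compound 2 to compound 3 (within the scatter), which stays within the scatter.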

Compound 3, a percentage reported as inhibition, at one concentration (the size of the read-out at that concentration, not a potency): -1.81%
Beside the measured number, compound 3's estimate is 5.8 percentage points above it; the range from low to high includes it.
By their numbers in this assay, from the lowest: compounds 3, 1 and 2 (each within the scatter of the next).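

Within the data shown here, compound 2 to compound 3 is the first step read at this position. In this assay, putting propyl in place of 3-fluorophenyl on a saturated chain carbon bound to a sulfur gives a number 6 percentage points lower from compound 2 to compound 3 (within the scatter) and so leaves the two compounds indistinguishable. The aromatic ring and its fluorine, both absent from compound 3, therefore make no readable difference here, although this says little about what the position can do, as both compounds sit at a low level where a small real effect could easily go unseen. No measurement is available that would explain this result.

Going by these compounds, what remains open is whether a more different group on this arm, such as an amine, a carboxylic acid or a longer chain, would move the number beyond the scatter. The benzyl group on the other sulfur is common to compound 2 and compound 3, so these two compounds also leave open how much that arm contributes to the low level seen.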